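The source may hold more compounds than are shown below. What is called first, only, known or untested is meant among the compounds shown, and "the series" means these compounds.

The compounds share one core, seen in compound 1 as `Cc1ccsc1-c1ccccc1NCC1=NCCN1`, and differ only in the group attached to one aromatic carbon. In a functional assay for activation of Alpha-1B adrenergic receptor (Homo sapiens), read by calcium flux (on this read-out higher numbers stand for an effect only at larger amounts of compound and lower numbers for an effect already at smaller amounts), compound 1 gives 112 nM. Among the two values shown, that is the only actual number. Compound 2, `FC(F)(F)c1cccnc1-c1ccccc1NCC1=NCCN1`, carries a different aromatic ring at the same place. In this assay compound 2 gives no number but a limit of the assay, < 100000 nM. The evidence on the measured compounds is thus (the limit of < 100000 nM in this assay, at which 1 of the 2 values shown sits). Compound 3, `CO/N=C(\C)c1ccccc1NCC1=NCCN1`, has not yet been measured. Compared with compound 1 it shows (a group of 5 heavy atoms (3 carbon, 1 nitrogen, 1 oxygen; no ring) in place of a group of 6 heavy atoms (5 carbon, 1 sulfur; one five-membered aromatic ring with 1 hetero atom), on an aromatic carbon); the five-membered aromatic ring with one hetero atom leaves, and a group with one double bond outside aromatic rings and two hydrogen-bond acceptors enters on that aromatic carbon. Among the measured compounds shown here, no measured pair makes this change, so its size is uncertain; the expectation is a loss of activity in this assay beyond the usual scatter, a step of a 13-fold higher number from compound 1 to compound 3 (1.13 log units; beyond the scatter). Compound 3 is therefore estimated at 1500 nM, within a range of 250 nM to 15000 nM.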

Compound 3, half-maximal effective concentration: < 5020 nM
Compound 3: only a limit was reported; the forecaster's own chance of this, stated with the estimate: 20%; the middle value is on the limit's open side.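

In this assay, among the compounds shown here, compound 3 gives only a limit of the assay, < 5020 nM, not a number, and no step from compound 1 to compound 3 can be read from it. The compounds shown leave open how large the effect is of replacing the 3-methylthiophen-2-yl group of compound 1 with the open-chain group of compound 3.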